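Replacing a Nonyl Chain with 4-Methylphenoxy on a Triazole

This account rests on a few compounds, and the source may have more. Where it says the series, first, only, none or still open, it means among the compounds named here.

Compound 1 `N#Cc1ccc(C(c2ccc(C#N)cc2)n2cc(COc3ccccc3)nn2)cc1` gives 11000 nM in an assay on isolated protein for inhibition of Aromatase (Homo sapiens), read by fluorescence and colorimetric assay, with a stated time of 30 min; a higher number here means a weaker inhibitor, a lower number a stronger inhibitor.
Compound 2 `Cc1ccc(OCc2cn(C(c3ccc(C#N)cc3)c3ccc(C#N)cc3)nn2)cc1` gives 11000 nM in this assay.
Compound 3 `CCCCCCCCCCc1cn(C(c2ccccc2)c2ccccc2)nn1` gives 13500 nM in this assay.

All three measured compounds share a triazole carrying a diarylmethyl group on one nitrogen. Compound 3 stands highest of the three numbers, but its nearest neighbour, compound 1, and its furthest, compound 2, are both within the usual scatter of it, so no order among the three can be claimed. Among the compounds with values here, the only step measured between two compounds differing in one place, no change at the digits printed from compound 1 to compound 2 (within the scatter), shows that a methyl added to the aromatic ring of the phenoxy group leaves the number unchanged.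

Compound 4 `Cc1ccc(OCc2cn(C(c3ccccc3)c3ccccc3)nn2)cc1` is obtained from compound 3 by the change (4-methylphenoxy in place of nonyl on a saturated chain carbon bound to an aromatic carbon). Within the data shown here, no measured step bears directly on this exchange; compound 2 carries the same 4-methylphenoxymethyl group but also two nitriles, so its value and that of compound 3 cannot be separated into the two changes. Since all three measured values sit together within the scatter, compound 4 is expected to remain near them, with a step of a 1.1-fold higher number from compound 3 to compound 4 (0.05 log units; within the scatter) and an estimated value of 15000 nM, between 5000 nM and 45000 nM.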

Compound 4, half-maximal inhibitory concentration: 26800 nM
For compound 4 the middle estimate is 1.8-fold (0.25 log units) below the measured one; the range from low to high includes it.
By their numbers in this assay, from the lowest: compounds 1, 2, 3 and 4 (each within the scatter of the next, the first and the last beyond it).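

The exchange of nonyl for 4-methylphenoxy on the shared core with two unsubstituted phenyl groups gives a 2.0-fold higher number from compound 3 to compound 4 (0.30 log units; within the scatter) in this assay. Within the data shown here, this is the first direct reading of the change at this place, and it shows that a saturated chain can give way to a group bringing an aromatic ring and a hydrogen-bond acceptor while the number stays within the scatter, although the step lies at its very edge. No measurement here accounts for the size of this step.

The compounds shown leave open whether an amine, a carboxylic acid or a longer chain at this place would carry the number beyond the scatter. They also leave open what a single nitrile on compound 4 would do, as the nitriles appear only in pairs, in compound 1 and compound 2.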